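From Bromo to Tert-Butyl in a Growth Test

The source may hold more compounds than are shown below. What is called first, only, known or untested is meant among the compounds shown, and "the series" means these compounds.

In a functional assay on SMMC-7721 cells (Homo sapiens) for inhibition, read by CCK-8 assay, with a stated time of 72 h, tested at 8 uM (a lower number here means less inhibition of growth, a higher number more inhibition of growth at the concentration tested), compound 2 `Nc1ccccc1NC(=O)c1ccc(CSc2ccc(Br)cc2)cc1` gives 25.3% as the lower of two numbers, while compound 1 `CCc1ccc(SCc2ccc(C(=O)Nc3ccccc3N)cc2)cc1` gives 82.9% as the higher. Compound 3 `CC(C)(C)c1ccc(SCc2ccc(C(=O)Nc3ccccc3N)cc2)cc1` differs from compound 2 by tert-butyl in place of bromo on an aromatic carbon with tert-butyl in place of bromo on an aromatic carbon. For the measured compounds named here, the only step bearing on this is a number 57.6 percentage points lower from compound 1 to compound 2 (beyond the scatter) with bromo in place of ethyl. Here bromo leaves in favour of a carbon group, so that step is expected to reverse in large part. The expected change is a number 42.7 percentage points higher from compound 2 to compound 3 (beyond the scatter) in this assay and so a large rise beyond the scatter. Compound 3 is estimated at 68% with 40% to 90% as its expected range.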

Compound 3, percent growth inhibition at one concentration: 46.1%
Beside the measured number, compound 3's estimate is 21.9 percentage points above it; the measured number falls inside the stated range.
By their numbers in this assay, from the lowest: compound 2; then compound 3; then compound 1.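

Swapping bromo for a carbon group at this position does not by itself restore the high number: the change to tert-butyl brings a number 20.8 percentage points higher from compound 2 to compound 3 (beyond the scatter) while the change from ethyl to tert-butyl brings a number 36.8 percentage points lower from compound 1 to compound 3 (beyond the scatter) and so leaves tert-butyl in the middle of the three. The two carbon groups are therefore not interchangeable here. Nothing available explains why they differ.

Going by these compounds, whether a longer chain such as propyl, or an amine, would sit closer to ethyl or to tert-butyl remains open.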